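Amino for methoxy on the benzamide of compound 2

A few compounds are considered here, and "the series" means these few. Any claim that something is new, unique, unknown or untested is made for them only; others in the source may bear on it.

Measured compounds:
- compound 1, `COc1ccc(OCC(=O)Nc2cccc(NC(=O)c3ccc(N(C)C)cc3)c2)cc1OC`: > 10000 nM
- compound 2, `COc1ccc(C(=O)Nc2cccc(NC(=O)COc3ccc4c(=O)ccoc4c3)c2)cc1`: 18 nM
- compound 3, `O=C(COc1ccc2c(=O)ccoc2c1)Nc1cccc(NS(=O)(=O)c2ccc(C(F)(F)F)cc2)c1`: > 10000 nM

Among the measured compounds shown here, in an assay on isolated protein for inhibition of Rho-associated protein kinase 1 (Homo sapiens), read by scintillation counting, radiometric assay and 33P incorporation, with a stated time of 40 min, in the presence of a further agent that is not named here (a lower number here means a stronger inhibitor, a higher number a weaker inhibitor), compound 2 gives 18 nM, the only numerical value in the set. For compound 1 the result is a limit of the assay, > 10000 nM. For compound 3 the result is likewise a limit, > 10000 nM. For the measured compounds named here, two of three results therefore sit at the limit of > 10000 nM in this assay, at which 2 of the 3 values shown sit, and no step between measured compounds is available.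

Compound 4, `Nc1ccc(C(=O)Nc2cccc(NC(=O)COc3ccc4c(=O)ccoc4c3)c2)cc1`, is not yet measured. It differs from compound 2 only in one place: amino in place of methoxy on an aromatic carbon. Going by the values given here, with no measured step to lean on, the expected step of a 1.4-fold higher number from compound 2 to compound 4 (0.14 log units; within the scatter) is one that does not go beyond the usual scatter in either direction. Compound 4 is therefore estimated at 25 nM in this assay, with a range from 8 nM to 80 nM.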

Compound 4, half-maximal inhibitory concentration: 802 nM
Compound 4: the middle estimate sits 32-fold (1.51 log units) below what was measured; measured number outside the range, above it.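

In this assay, among the compounds shown here, the change from 4-methoxyphenyl to 4-aminophenyl gives a 45-fold higher number from compound 2 to compound 4 (1.65 log units; beyond the scatter), the first single-place step. The position para to a large group therefore responds strongly to this exchange, although compound 4 still gives a number rather than a limit of the assay. Nothing measured here accounts for the size of this step. Still open, from the compounds shown here alone, is whether a hydroxyl or an ethoxy group at this place would read closer to compound 2 or to compound 4. Also open, going by these compounds, is whether a methylamino group would recover any of the difference.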